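The source may hold more compounds than are shown below. What is called first, only, known or untested is meant among the compounds shown, and "the series" means these compounds.

Working notes on the series. In a functional assay on MDA-MB-468 cells (Homo sapiens) for antiproliferative activity, read by MTT assay, with a stated time of 72 h (on this read-out lower numbers stand for stronger inhibition and higher numbers for weaker inhibition), compound 1 (`COc1cc(-c2nccn2CC(C)C)cc(OC)c1OC`) gives > 100000 nM, which is a limit of the assay and not a number. Compound 1 therefore stands at the limit of > 100000 nM in this assay, at which 1 of the 2 values shown sits. Compound 2 (`COc1ccc(-n2ccnc2-c2cc(OC)c(OC)c(OC)c2)cc1[N+](=O)[O-]`) gives a measured 100 nM in this assay. Compound 3 (`COc1cc(-c2nccn2-c2ccc(Br)cc2)cc(OC)c1OC`) keeps the core of compound 1 and changes one substituent: 4-bromophenyl in place of isobutyl on an aromatic nitrogen. In words, 4-bromophenyl takes the place of isobutyl on an aromatic nitrogen. Compound 2, at 100 nM, also carries a six-membered aromatic ring of carbon only on that nitrogen, and the expectation rests on this single comparison. The expected step is an at least 100-fold lower number from compound 1 to compound 3 (2.00 log units; beyond the scatter), towards stronger inhibition and beyond the usual scatter. For compound 3 the estimate is 1000 nM, with an expected range of 100 nM to 20000 nM.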

Compound 3, half-maximal inhibitory concentration: 2700 nM
For compound 3 the middle estimate is 2.7-fold (0.43 log units) below the measured one, and the stated range covers the measured number.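

Within the data shown here, on the aromatic nitrogen of the shared core, 4-bromophenyl in place of isobutyl gives an at least 37-fold lower number from compound 1 to compound 3 (1.56 log units; beyond the scatter) in this assay, the first reading of this position from a single change. The value for compound 1 is a limit and not a number, so the step gives only a lower bound on the size of the change: the limit of > 100000 nM in this assay, at which 1 of the 3 values shown sits. Among compounds with a six-membered aromatic ring of carbon only on that nitrogen, compound 3 gives 2700 nM and compound 2 gives 100 nM, so having that ring there does not alone set the value.

As far as these compounds go, whether the ring itself is needed remains open, as a benzyl group or a longer chain on that nitrogen could show. Also open, from the compounds shown here alone, is how an amine or a carboxylic acid on the ring in place of bromine would read.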